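A few compounds are considered here, and "the series" means these few. Any claim that something is new, unique, unknown or untested is made for them only; others in the source may bear on it.

Measured so far in a functional assay for inhibition, with Homo sapiens as the target; on this read-out higher numbers stand for weaker inhibition and lower numbers for stronger inhibition:
- compound 1, `CC1CCN(c2ccc(Nc3nccc(-c4cccnc4)n3)cc2)CC1`, 500 nM
- compound 2, `CC(=O)Nc1ccc(Nc2nccc(-c3cccnc3)n2)cc1`, 3600 nM
- compound 3, `CN(C)CCCOc1ccc(Nc2nccc(-c3cccnc3)n2)cc1`, 600 nM

Compound 3 stands second highest of the three numbers; its nearest neighbour is compound 1, with a 1.2-fold higher number from compound 1 to compound 3 (0.08 log units; within the scatter), while the gap to compound 2 is wider, shown by a 6.0-fold lower number from compound 2 to compound 3 (0.78 log units; beyond the scatter).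

Compound 4, `Oc1ccc(Nc2nccc(-c3cccnc3)n2)cc1`, has not been measured. It differs from compound 3 by hydrogen in place of 3-(dimethylamino)propyl on an oxygen on an aromatic ring. Among the measured compounds shown here, no measured step removes a chain from the oxygen in this way, so the guidance is indirect. For the measured compounds named here, the two steps that bear on it are a 7.2-fold higher number from compound 1 to compound 2 (0.86 log units; beyond the scatter) and a 6.0-fold lower number from compound 2 to compound 3 (0.78 log units; beyond the scatter): the one measured compound that carries no nitrogen-containing side group, compound 2, gives the highest number, and each step from compound 2 to a compound with such a group lowers the number by a modest amount. Compound 4 also lacks such a group, keeping only a hydroxy, so a higher number than compound 3 is expected, most likely a step of roughly the size seen in those two pairs, though the new end group is not one already measured.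

For compound 4 in this assay the expected step is a 4.2-fold higher number from compound 3 to compound 4 (0.62 log units; beyond the scatter), giving an estimate of 2500 nM, with a range from 800 nM to 8000 nM.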

Compound 4, half-maximal inhibitory concentration: 5100 nM
The estimate for compound 4 lay 2.0-fold (0.31 log units) below the measured number, within the range that was stated.
By their numbers in this assay, from the lowest: compounds 1 and 3 (each within the scatter of the next); then compounds 2 and 4 (each within the scatter of the next).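

In this assay, taking the 3-(dimethylamino)propyl chain off the oxygen on the aromatic ring gives an 8.5-fold higher number from compound 3 to compound 4 (0.93 log units; beyond the scatter), so the oxygen left alone as a hydroxy does not keep the low number that compound 3 shows. The hydroxy instead lands level with the acetamido group, with a 1.4-fold higher number from compound 2 to compound 4 (0.15 log units; within the scatter), while the change from the 4-methylpiperidin-1-yl group is the largest of the new steps, with a 10-fold higher number from compound 1 to compound 4 (1.01 log units; beyond the scatter). The four compounds thus fall into two sets, with the two carrying an amine in the side group, compounds 1 and 3, at the low end and the two without one, compounds 2 and 4, at the high end, and none of the four goes against this split.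

No independent evidence is available to explain this split. The compounds shown leave open whether the amine itself or simply the length of the chain sets the number, a question that a methoxy group, a plain propoxy chain or a propoxy chain ending in a carboxylic acid on the same oxygen would bear on.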